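The source may report more compounds than this note shows. Statements on the series, on what has been measured and on what is new or still open speak of the compounds shown alone.

Of the compounds shown here, three built on one shared core have been measured in a functional assay on U-87MG ATCC cells for inhibition, with U-87 MG (Homo sapiens) as the target, read by MTT assay, with a stated time of 72 h; a higher number here means a weaker inhibitor, a lower number a stronger inhibitor. Compound 1 `Cc1noc(C)c1-c1cnc(N)c(Oc2ccc(C(=O)NC3CC3)cc2)n1` gives 43300 nM, compound 2 `Cc1noc(C)c1-c1cnc(N)c(Oc2ccc(C(=O)Nc3ccccc3Cl)cc2)n1` gives 60500 nM, and compound 3 `Cc1noc(C)c1-c1cnc(N)c(Oc2ccc(C(=O)Nc3cccc(Cl)c3)cc2)n1` gives 11500 nM. Compound 3 stands lowest of the three numbers: the step of a 3.8-fold lower number from compound 1 to compound 3 (0.58 log units; beyond the scatter) and the step of a 5.3-fold lower number from compound 2 to compound 3 (0.72 log units; beyond the scatter) both reach beyond the scatter, while a 1.4-fold higher number from compound 1 to compound 2 (0.15 log units; within the scatter) does not. Compound 4 `Cc1noc(C)c1-c1cnc(N)c(Oc2ccc(C(=O)Nc3cc(Cl)ccn3)cc2)n1` has not yet been measured. It differs from compound 3 in one place: 4-chloropyridin-2-yl in place of 3-chlorophenyl on an amide-type nitrogen. Among the compounds with values here, no measured step swaps a carbon-only ring for a ring holding a nitrogen on this amide-type nitrogen, so nothing measured bears on the change directly. What the measured steps do show is that the group on this nitrogen can shift the number by a modest amount, as in a 5.3-fold lower number from compound 2 to compound 3 (0.72 log units; beyond the scatter). Because compound 3 gives 11500 nM, the lowest number seen so far, and the new group keeps a chlorine but carries it on a different ring, a modest rise toward the other two compounds seems more likely than a further fall, though the direction remains uncertain. Compound 4 is therefore estimated at 20000 nM, between 6000 nM and 60000 nM, an expected step of a 1.7-fold higher number from compound 3 to compound 4 (0.24 log units; within the scatter) that may stay within the scatter.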

Compound 4, half-maximal inhibitory concentration: 70800 nM
For compound 4 the middle estimate is 3.5-fold (0.55 log units) below the measured one, outside the stated range (above it).
By their numbers in this assay, from the lowest: compound 3; then compounds 1, 2 and 4 (each within the scatter of the next).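

In this assay, compound 3 and compound 4 both carry a chlorine on a six-membered aromatic ring, yet the change to 4-chloropyridin-2-yl gives a 6.2-fold higher number from compound 3 to compound 4 (0.79 log units; beyond the scatter) and so removes the advantage held by compound 3. Within the data shown here, two further comparisons place compound 4 level with the others, as a 1.2-fold higher number from compound 2 to compound 4 (0.07 log units; within the scatter) and a 1.6-fold higher number from compound 1 to compound 4 (0.21 log units; within the scatter) both stay within the scatter, which leaves compound 3 as the strongest inhibitor of the four and 3-chlorophenyl as the only group on this amide-type nitrogen that stands apart from the rest. Nothing available explains why this change has such an effect.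

The new group differs from 3-chlorophenyl both in its ring nitrogen and in the numbered place of its chlorine, so the compounds shown cannot tell which of the two accounts for the step. They also leave open how an unsubstituted pyridin-2-yl ring, or a phenyl ring bearing a methoxy group or a carboxylic acid in place of the chlorine, would fare on this nitrogen.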